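The source may hold more compounds than are shown below. What is called first, only, known or untested is meant among the compounds shown, and "the series" means these compounds.

Working notes on a hydroxamate series sharing one core, read in a functional assay on HepG2 cells (Homo sapiens) for inhibition, read by MTT assay, with a stated time of 72 h; on this read-out lower numbers stand for stronger inhibition and higher numbers for weaker inhibition.

Compound 1 `Nc1ncnc2c1c(-c1cnc3[nH]ccc3c1)nn2CCCCCCCCC(=O)NO` carries the longest chain; in this assay compound 1 gives 3050 nM. Compound 3 `Nc1ncnc2c1c(-c1cnc3[nH]ccc3c1)nn2CCCCCCC(=O)NO` is shorter by two chain carbons; in this assay compound 3 gives 10300 nM, and the step is a 3.4-fold higher number from compound 1 to compound 3 (0.53 log units; beyond the scatter). Compound 2 `Nc1ncnc2c1c(-c1cnc3[nH]ccc3c1)nn2CCCCC(=O)NO` is shorter again; in this assay compound 2 gives 36700 nM, with a 3.6-fold lower number from compound 2 to compound 3 (0.55 log units; beyond the scatter) and a 12-fold higher number from compound 1 to compound 2 (1.08 log units; beyond the scatter). Across these three, each shortening of the chain goes with a higher number; no measured compound goes against this.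

Compound 4 `Nc1ncnc2c1c(-c1cnc3[nH]ccc3c1)nn2CCC(=O)NO` is not yet measured. It differs from compound 3 by hydroxycarbamoyl in place of 4-(hydroxycarbamoyl)butyl on a saturated chain carbon, two bonds along the chain from an aromatic nitrogen. The same kind of change is already measured once, from compound 1 to compound 2 as hydroxycarbamoyl in place of 4-(hydroxycarbamoyl)butyl on a saturated chain carbon, four bonds along the chain from an aromatic nitrogen, where it made a 12-fold higher number from compound 1 to compound 2 (1.08 log units; beyond the scatter). The cores of compound 1 and compound 3 differ by hydroxycarbamoyl in place of 2-(hydroxycarbamoyl)ethyl on a saturated chain carbon, six bonds along the chain from an aromatic nitrogen; the place lines are not identical, since the change sits two bonds along the chain from an aromatic nitrogen in compound 4 but four bonds along in compound 2, so this is the same kind of change rather than the same one.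

Resting on compound 1 to compound 2 giving a 12-fold higher number from compound 1 to compound 2 (1.08 log units; beyond the scatter), the step from compound 3 to compound 4 is expected to be about an 11-fold higher number from compound 3 to compound 4 (1.03 log units; beyond the scatter). Compound 4 is therefore estimated at 110000 nM in this assay. The expected range for compound 4 runs from 35000 nM to 350000 nM, and a limit rather than a number is possible.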

Compound 4, half-maximal inhibitory concentration: > 150000 nM
Compound 4: no number, only a limit; the forecaster's own chance of this, stated with the estimate: 35%; middle value at least 1.3-fold (0.13 log units) from the limit.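

In this assay compound 4 gives > 150000 nM, which is a limit of the assay and not a number. The change from 4-(hydroxycarbamoyl)butyl to hydroxycarbamoyl keeps its direction on the core of compound 3, with an at least 14-fold higher number from compound 3 to compound 4 (1.16 log units; beyond the scatter), but whether its size carries over remains unsettled: the same change on two cores in this assay, a 12-fold higher number (1.08 log units; beyond the scatter) from compound 1 to compound 2 and an at least 14-fold higher number (1.16 log units; beyond the scatter) from compound 3 to compound 4; the limit leaves it open whether they differ The change from 2-(hydroxycarbamoyl)ethyl to hydroxycarbamoyl likewise keeps its direction, with an at least 4.0-fold higher number from compound 2 to compound 4 (0.61 log units; beyond the scatter), and again shows nothing firm about its size: the same change on two cores in this assay, a 3.4-fold higher number (0.53 log units; beyond the scatter) from compound 1 to compound 3 and an at least 4.0-fold higher number (0.61 log units; beyond the scatter) from compound 2 to compound 4; the limit leaves it open whether they differ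

The widest change in the series, with an at least 49-fold higher number from compound 1 to compound 4 (1.69 log units; beyond the scatter), also rests on the limit, so the true distance across the four compounds stays open, although each shortening of the chain goes with a higher number and no compound shown goes against this. Also open, as far as these compounds go, is whether a longer chain than that of compound 1 would continue this order, and how a carboxylic acid in place of hydroxycarbamoyl would read on the shared core.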